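A few compounds are considered here, and "the series" means these few. Any claim that something is new, unique, unknown or untested is made for them only; others in the source may bear on it.

Compound 1 `Cc1ccc(C2=NN(C(N)=S)C(c3ccc(Cl)cc3)C2)cc1` gives 31 nM in an assay on mitochondria for inhibition of Amine oxidase [flavin-containing] A (Bos taurus); on this read-out lower numbers stand for stronger inhibition and higher numbers for weaker inhibition; compound 2 `NC(=S)N1N=C(c2ccc(F)cc2)CC1c1ccc(Cl)cc1` gives 6 nM.

Compound 2 thus stands lowest of the two numbers, set apart from compound 1 by a 5.2-fold lower number from compound 1 to compound 2 (0.71 log units; beyond the scatter). Compound 3 `NC(=S)N1N=C(c2cccs2)CC1c1ccc(Cl)cc1` differs from compound 2 by thiophen-2-yl in place of 4-fluorophenyl on a carbon with a double bond to nitrogen. Among the compounds with values here, the single measured step, fluoro in place of methyl on an aromatic carbon, changed only a substituent on the group that now departs, so it bears loosely on exchanging that whole ring, and no step tests a thiophen-2-yl. Compound 3 is therefore expected to give 10 nM (range 3 nM to 35 nM), an expected step of a 1.7-fold higher number from compound 2 to compound 3 (0.22 log units; within the scatter), likely within the scatter.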

Compound 3, inhibition constant: 41 nM
Compound 3: middle estimate off by 4.1-fold (0.61 log units), on the low side; the measured number lies above the stated range.
By their numbers in this assay, from the lowest: compound 2; then compounds 1 and 3 (each within the scatter of the next).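

In this assay, exchanging the whole ring on this carbon matters as much as changing a substituent on it (in numbers, a 6.8-fold higher number from compound 2 to compound 3 (0.83 log units; beyond the scatter)). Set against the 4-methylphenyl group of compound 1, thiophen-2-yl makes no clear difference (a 1.3-fold higher number from compound 1 to compound 3 (0.12 log units; within the scatter)), so among these three groups only the 4-fluorophenyl of compound 2 stands apart. Nothing measured here explains this.

Going by these compounds, whether a pyridin-2-yl ring or a 4-chlorophenyl group on this carbon would match compound 2 remains open. So does the effect of a cyclohexyl ring.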